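Adding a second bromo group to compound 3

A few compounds are considered here, and "the series" means these few. Any claim that something is new, unique, unknown or untested is made for them only; others in the source may bear on it.

Of the compounds shown here, three sharing one core have been measured in a physicochemical assay for lipophilicity; on this read-out higher numbers stand for higher lipophilicity and lower numbers for lower lipophilicity. Compound 1 `CC(C)c1nc2ccccc2[nH]1` gives 2.41, compound 2 `c1ccc2cc(Cc3nc4ccccc4[nH]3)ccc2c1` gives 4.79, and compound 3 `Brc1ccccc1OCc1nc2ccccc2[nH]1` gives 3.51. Compound 3 stands second highest of the three, with compound 1 lower and compound 2 higher, and both gaps lie beyond the scatter.

Compound 4 `Brc1ccc(OCc2nc3ccccc3[nH]2)c(Br)c1` differs from compound 3 in one place: bromo in place of hydrogen on an aromatic carbon. This is bromo in place of hydrogen on an aromatic carbon, meta to a bromo group and para to a large group.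

Among the measured compounds shown here, no two measured compounds differ in only one place, so the data offer no direct precedent for this change. The expectation therefore starts from compound 3 at 3.51 and rests on the added bromo group alone. The expected step is a number 0.84 log units higher from compound 3 to compound 4 (beyond the scatter), a moderate rise beyond the scatter in this assay. For compound 4 the estimated value is 4.35, with an expected range of 3.95 to 4.75.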

Compound 4, partition coefficient: 4.52
Compound 4: the middle estimate sits 0.17 log units below what was measured; the range from low to high includes it.
By their numbers in this assay, from the lowest: compound 1; then compound 3; then compounds 4 and 2 (each within the scatter of the next).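

In this assay, bromo in place of hydrogen on an aromatic carbon, meta to a bromo group and para to a large group, goes with a number 1.01 log units higher from compound 3 to compound 4 (beyond the scatter) and is classed as large. Among the compounds shown here, this is the first one-place step, and it shows that a ring already carrying a bromo group can take a second one at this position with a clear shift in the read-out. Nothing measured bears on the reason for this step, so it stands as an observation only.

A single step cannot show whether a change of this size is specific to this position or would recur elsewhere on the ring. It also leaves open how a chloro group, a methoxy group or an amine at the same place would compare with bromo.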